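Removing one trifluoromethyl from a bis(trifluoromethyl)phenyl urea

The source may report more compounds than this note shows. Statements on the series, on what has been measured and on what is new or still open speak of the compounds shown alone.

Three ureas share a core and differ in the terminal aryl ring. In a functional assay on ACHN cells (Homo sapiens) for inhibition, read by sulforhodamine B assay, with a stated time of 48 h, tested at 1 uM (a higher number here means a weaker effect of the compound at the concentration tested, a lower number a stronger effect), compound 1 `O=C(Nc1cccc(-n2cc(-c3ccncc3)c(-c3cc(O)cc(Cl)c3)n2)c1)Nc1ccc(Cl)c(C(F)(F)F)c1` gives 92%, and compound 2 `O=C(Nc1cccc(-n2cc(-c3ccncc3)c(-c3cc(O)cc(Cl)c3)n2)c1)Nc1ccc(Cl)c(Cl)c1` gives 79%; the change between them is a number 13 percentage points lower from compound 1 to compound 2 (beyond the scatter). Compound 3 `COc1cc(Cl)cc(-c2nn(-c3cccc(NC(=O)Nc4cc(C(F)(F)F)cc(C(F)(F)F)c4)c3)cc2-c2ccncc2)c1` gives 17%, the lowest of the three numbers, beyond the scatter from both compound 2 and compound 1. Compound 4 `COc1cc(Cl)cc(-c2nn(-c3cccc(NC(=O)Nc4cccc(C(F)(F)F)c4)c3)cc2-c2ccncc2)c1` differs from compound 3 by hydrogen in place of trifluoromethyl on an aromatic carbon. Going by the values given here, only the step from compound 1 to compound 2, a modest one, touches a substituent on that ring, and no measured step removes a trifluoromethyl outright, so the expectation is uncertain. A step of a number 28 percentage points higher from compound 3 to compound 4 (beyond the scatter) toward a weaker effect is expected, and compound 4 is estimated at 45%, between 15% and 85%.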

Compound 4, a percentage reported as activity, at one concentration (the size of the read-out at that concentration, not a potency): 65%
Compound 4: middle estimate off by 20 percentage points, on the low side, and the stated range covers the measured number.
By their numbers in this assay, from the lowest: compound 3; then compound 4; then compound 2; then compound 1.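

In this assay, going by these compounds alone, hydrogen in place of trifluoromethyl gives a number 48 percentage points higher from compound 3 to compound 4 (beyond the scatter), a large step toward a weaker effect and the first measured step to remove a trifluoromethyl outright. A single trifluoromethyl remaining on the ring in compound 4 therefore does not keep the read-out at the level of compound 3. Nothing available accounts for the size of this step. Still open, on these data alone, is whether a nitrile or a tert-butyl group at this position would match trifluoromethyl, and whether the same removal behaves alike with the hydroxyl of compound 1 on the core.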